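Removing the chloro from the hydrazone of compound 2

This account rests on a few compounds, and the source may have more. Where it says the series, first, only, none or still open, it means among the compounds named here.

Two compounds of the same series have been examined so far: compound 1 `COc1ccc(OC)c(/C=C/c2nnc(Nc3ccc(Cl)cc3)o2)c1` and compound 2 `COc1ccc(OC)c(/C=C/C(=O)N/N=C/c2ccc(Cl)cc2)c1`. In a functional assay on UACC-257 cells (Homo sapiens) for antiproliferative activity, read by sulforhodamine B assay, with a stated time of 48 h (on this read-out lower numbers stand for higher toxicity in this test and higher numbers for lower toxicity in this test), compound 1 gives no number, only a limit of the test, > 100000 nM. Compound 2 in this assay also reaches only a limit, > 100000 nM. Compound 2 therefore stands at the limit of > 100000 nM in this assay, at which 2 of the 2 values shown sit, and no figure sets it apart from compound 1. The next member is compound 3 `COc1ccc(OC)c(/C=C/C(=O)N/N=C/c2ccccc2)c1`, which differs from compound 2 by hydrogen in place of chloro on an aromatic carbon. No measured pair differs at this place, and the weight of this change is not known from the numbers shown. The expected step in this assay is a step that the limit leaves unreadable from compound 2 to compound 3, nothing beyond the usual scatter. Compound 3 is estimated at 150000 nM, within a range from 40000 nM to 600000 nM, most likely once more reported as a limit.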

Compound 3, concentration lethal to 50% of the cells: > 100000 nM
Compound 3 gave a limit, no number; the forecaster's own chance of this, stated with the estimate: 85%; the middle value lies beyond the limit too.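

Compound 2 and compound 3 each reach only a limit in this assay, so no step can be read between them. The compounds shown leave open how any of them ranks against the others, and whether the change from 4-chlorophenyl to phenyl matters: the limit of > 100000 nM in this assay, at which 3 of the 3 values shown sit.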